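This account rests on a few compounds, and the source may have more. Where it says the series, first, only, none or still open, it means among the compounds named here.

Compound 3, with the structure `Cc1nc(S(C)(=O)=O)ccc1Oc1ncnc(OC2CCN(C(=O)SC3CC3)CC2)c1F`, carries a cyclopropyl on a sulfur attached to the carbonyl carbon of the shared core. Within the data shown here, in a functional assay on isolated protein for inhibition of Glucose-dependent insulinotropic receptor (Rattus norvegicus), read by HTRF and cAMP accumulation (a higher number here means a larger maximal response, a lower number a smaller maximal response), compound 3 gives 80%, which sits level with compound 2 `Cc1nc(S(C)(=O)=O)ccc1Oc1ncnc(OC2CCN(C(=O)O[C@@H](C)C(F)(F)F)CC2)c1F` at 80%, and the two together stand at the top of the three numbers measured so far. Compound 1 `Cc1nc(S(C)(=O)=O)ccc1Oc1ncnc(OC2CCN(C(=O)OC(C)C)CC2)c1F` gives 77% in this assay.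

The three measured compounds differ only in the group on the carbonyl carbon. The steps among them are small: a number 3 percentage points higher from compound 1 to compound 2 (within the scatter), a number 3 percentage points higher from compound 1 to compound 3 (within the scatter), and no change at the digits printed from compound 2 to compound 3 (within the scatter). Every one of these lies within the scatter, so swapping groups at this position has so far left the maximal response essentially unchanged.

Compound 4, with the structure `Cc1nc(S(C)(=O)=O)ccc1Oc1ncnc(OC2CCN(C(=O)SC3CCC3)CC2)c1F`, differs from compound 3 only in cyclobutyl in place of cyclopropyl on a sulfur. Among the measured compounds shown here, no measured step covers exactly this ring enlargement, but the related steps at the same position all stayed within the scatter, so for this assay no movement beyond the scatter is expected from compound 3 to compound 4, that is no change at the digits printed from compound 3 to compound 4 (within the scatter). Compound 4 is therefore expected to give about 80% in this assay, with a range from 70% to 90%.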

Compound 4, largest response reached (reported as efficacy), in percent of the reference or control that the assay uses: 81%
Compound 4: the middle estimate sits 1 percentage points below what was measured, within the range that was stated.
By their numbers in this assay, from the lowest: compounds 1, 2, 3 and 4 (each within the scatter of the next).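

In this assay, among these compounds, the first step that changes only the ring on the sulfur stays within the scatter: a number 1 percentage points higher from compound 3 to compound 4 (within the scatter) shows that cyclobutyl and cyclopropyl cannot be told apart at this place. The sulfur-linked cyclobutyl also stays within the scatter of both oxygen-linked groups, with a number 1 percentage points higher from compound 2 to compound 4 (within the scatter) and a number 4 percentage points higher from compound 1 to compound 4 (within the scatter) in the same assay, so the flat picture now covers four different groups on the carbonyl carbon. Nothing available explains why the maximal response holds so steady across these groups.

Still open, from the compounds shown here alone, is whether this tolerance extends to quite different groups, such as an amine in place of the sulfur on the carbonyl carbon, or a cyclohexyl or phenyl ring on the sulfur. Also open, going by these compounds, is whether cyclobutyl on an oxygen would read the same as cyclobutyl on a sulfur, a direct swap of the linking atom that would separate its contribution from that of the ring.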